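The source may hold more compounds than are shown below. What is called first, only, known or untested is meant among the compounds shown, and "the series" means these compounds.

Compound 1 `CCCCCCn1cnc2c(Nc3ccc(O)cc3)nc(N[C@H]3CC[C@H](N)CC3)nc21` is one of three compounds sharing the same core, each carrying an amine-bearing saturated ring on one side and an aromatic amine on the other. In a functional assay on K562 cells (Homo sapiens) for inhibition, read by fluorescence, with a stated time of 72 h (a higher number here means a weaker inhibitor of growth, a lower number a stronger inhibitor of growth), compound 1 gives 5400 nM, the highest of the three numbers, although its gaps to both companions fall within the scatter. Compound 2 `COc1ccc(Cn2cnc3c(Nc4cccc(Cl)c4)nc(N[C@H]4CC[C@H](N)CC4)nc32)cc1` gives 2800 nM in this assay, and compound 3 `N[C@H]1CC[C@H](Nc2nc(Nc3cccc(Cl)c3)c3ncn(Cc4ccccc4)c3n2)CC1` gives 3000 nM. Going by the values given here, the only measured step, a 1.1-fold higher number from compound 2 to compound 3 (0.03 log units; within the scatter), concerns a substituent on the aromatic amine and leaves the chain on the core nitrogen untouched.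

Compound 4 `CC(C)CCn1cnc2c(Nc3ccc(O)cc3)nc(N[C@H]3CC[C@H](N)CC3)nc21` differs from compound 1 in one place: isopropyl in place of butyl on a saturated chain carbon, two bonds along the chain from an aromatic nitrogen. Among the compounds with values here, no measured pair changes this chain, so there is no step of the same kind to draw on, and the single step that does exist lies elsewhere on the molecule and stays within the scatter. With nothing pointing either way, the sensible expectation for this assay is a step no larger than the scatter, in no particular direction.

Compound 4 is therefore expected to give about 5000 nM in this assay, with a range from 2000 nM to 12000 nM. The estimated step of a 1.1-fold lower number from compound 1 to compound 4 (0.03 log units; within the scatter) is expected to remain within the scatter.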

Compound 4, concentration for 50% growth inhibition: 4600 nM
For compound 4 the middle estimate is 1.1-fold (0.04 log units) above the measured one; low and high end bracket the measured number.
By their numbers in this assay, from the lowest: compounds 2, 3, 4 and 1 (each within the scatter of the next).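

Going by these compounds alone, compounds 1 and 4 form the only measured pair that changes the chain on the aromatic nitrogen of the shared core. In this assay, turning hexyl into isopentyl gives a 1.2-fold lower number from compound 1 to compound 4 (0.07 log units; within the scatter) as the step, so this pair shows that the straight chain can end in a branch without a change in growth inhibition that stands out from the scatter of repeated measurements. Nothing measured here bears on why the two chains read alike.

From the compounds shown here alone, whether the same holds for a chain much longer than hexyl, or for one ending in an amine or a carboxylic acid, stays open, since this single pair covers only two closely related alkyl chains. Compounds 2 and 3, with their benzyl-type groups on that nitrogen, also differ from compounds 1 and 4 on the aromatic amine, so the effect of replacing an alkyl chain with a ring-bearing group on its own cannot be read from these compounds.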